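A few compounds are considered here, and "the series" means these few. Any claim that something is new, unique, unknown or untested is made for them only; others in the source may bear on it.

Compounds measured so far:

Compound 1 `O=C(Nc1cccc(-n2cc(-c3ccncc3)c(-c3cc(O)cc(Cl)c3)n2)c1)Nc1ccc(Cl)c(C(F)(F)F)c1`: 59.3%
Compound 2 `COc1cc(Cl)cc(-c2nn(-c3cccc(NC(=O)Nc4ccc(Cl)c(C(F)(F)F)c4)c3)cc2-c2ccncc2)c1`: 19.2%
Compound 3 `COc1cc(Cl)cc(-c2nn(-c3cccc(NC(=O)Nc4cc(C(F)(F)F)cc(C(F)(F)F)c4)c3)cc2-c2ccncc2)c1`: 21.7%

In a functional assay on OVCAR-5 cells (Homo sapiens) for inhibition, read by sulforhodamine B assay, with a stated time of 48 h, tested at 10 uM (a higher number here means a weaker effect of the compound at the concentration tested, a lower number a stronger effect), compound 2 gives the lowest of the three numbers. Its nearest neighbour is compound 3, whose value of 21.7% lies within the scatter of that of compound 2, so the two cannot be told apart. For the measured compounds named here, the furthest is compound 1, and the single step in the set, a number 40.1 percentage points lower from compound 1 to compound 2 (beyond the scatter), is large and beyond the scatter.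

Compound 4 `COc1cc(Cl)cc(-c2nn(-c3cccc(NC(=O)c4cccc(C(F)(F)F)c4)c3)cc2-c2ccncc2)c1` is not yet measured. It differs from compound 2 in one place: 3-(trifluoromethyl)phenyl in place of (4-chloro-3-(trifluoromethyl)phenyl)amino on a carbonyl carbon. Going by the values given here, no measured step concerns this part of the molecule. Among the compounds with values here, the only step on record, a number 40.1 percentage points lower from compound 1 to compound 2 (beyond the scatter), sits on an oxygen on an aromatic ring far from the carbonyl carbon and gives no guidance here. Compounds 2 and 3 show that two different aryl groups on the amino side of the carbonyl give values within the scatter of each other, but neither removes the amino group itself. Since one hydrogen-bond donor and the chlorine leave with this change, a weakening is expected, of uncertain size. The estimated value for compound 4 is 40%, in the range 15% to 70%, which corresponds to an expected step of a number 20.8 percentage points higher from compound 2 to compound 4 (beyond the scatter).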

Compound 4, a percentage reported as activity, at one concentration (the size of the read-out at that concentration, not a potency): 84.1%
Estimate against measurement, compound 4: 44.1 percentage points below; the measured number lies above the stated range.
By their numbers in this assay, from the lowest: compounds 2 and 3 (each within the scatter of the next); then compound 1; then compound 4.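

In this assay the carbonyl carbon proves to be a place where a single change matters greatly: 3-(trifluoromethyl)phenyl in place of (4-chloro-3-(trifluoromethyl)phenyl)amino gives a number 64.9 percentage points higher from compound 2 to compound 4 (beyond the scatter) and so takes away most of the effect seen at the concentration tested. Compounds 1, 2 and 3 all keep an amino group on the carbonyl carbon, so only compound 4 shows what happens when that group is gone, and in this change the amino group, with its hydrogen-bond donor, leaves together with the chlorine. No measurement at hand accounts for the size of this step.

The compounds shown leave open how much of the step belongs to the amino group and how much to the chlorine, since both leave at once. They also leave open whether a methylene or a methylamino group on the carbonyl carbon, with the 4-chloro-3-(trifluoromethyl)phenyl group kept in place, would hold the stronger effect of compound 2 or lose it as compound 4 does.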